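The compounds below may be only part of what the source reports. "The series", "measured", "known", "first", "only" and "open" are said of these compounds alone.

Compound 1, `O=S(=O)(Nc1ccc(-c2nc3ccccc3o2)cc1)c1ccc(F)c(C(F)(F)F)c1`: > 63000 nM in an assay on isolated protein for inhibition of malate dehydrogenase, mitochondrial (Sus scrofa), with stated times of 45 min and 30 min; on this read-out lower numbers stand for stronger inhibition and higher numbers for weaker inhibition
Compound 2, `Cc1cccc(S(=O)(=O)Nc2ccc(-c3nc4ccccc4o3)cc2)c1`: > 63000 nM
Compound 3, `O=S(=O)(Nc1ccc(-c2nc3ccccc3o2)cc1)c1ccc(Cl)c(C(F)(F)F)c1`: > 63000 nM

The value of compound 1 is a limit of this assay, not a measured number. The value of compound 2 is likewise a limit. The value of compound 3 is a limit as well, so that all three sit at the same edge, as the limit of > 63000 nM in this assay, at which 3 of the 3 values shown sit, records. Compound 2 therefore stands only at a limit in this assay, with no number of its own to compare against the other two.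

Within the data shown here, the single step between compounds that differ in one place, a step that the two limits leave unreadable from compound 1 to compound 3, runs from one limit to another and cannot be read in size or direction.

Compound 4, `COc1cccc(S(=O)(=O)Nc2ccc(-c3nc4ccccc4o3)cc2)c1`, differs from compound 2 by methoxy in place of methyl on an aromatic carbon. Among the measured compounds shown here, no measured step bears on this change; the only step available is unreadable. What can be expected for compound 4 rests on compound 2 sitting at the limit. The step that the limit leaves unreadable from compound 2 to compound 4 is expected to be none beyond the scatter. Compound 4 is estimated at 100000 nM, with a range from 30000 nM to 300000 nM, and most likely another limit.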

Compound 4, half-maximal inhibitory concentration: > 63000 nM
Compound 4 was reported as a limit; the forecaster's own chance of this, stated with the estimate: 85%; the middle value is on the limit's open side.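

In this assay compound 4 is reported only as a limit, as compound 2 is, so no step can be read between compound 2 and compound 4. All the results shown sit at one edge: the limit of > 63000 nM in this assay, at which 4 of the 4 values shown sit. The compounds shown leave open whether methoxy and methyl differ at all, and what number any of these compounds would give.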